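This account rests on a few compounds, and the source may have more. Where it says the series, first, only, none or still open, it means among the compounds named here.

Measured compounds:
Compound 1 `O=C(Nc1cccc(Cl)c1)c1cc(Br)cc(Br)c1O` — in an assay on isolated protein for inhibition of thiosulfate sulfurtransferase (Homo sapiens), with a stated time of 60 min, in the absence of a further agent (a lower number here means a stronger inhibitor, a higher number a weaker inhibitor), compound 1 gives > 100000 nM, which is a limit of the assay and not a number.
Compound 2 `O=C(Nc1cccc(Cl)c1)c1cc(Br)cc(Br)c1` — in this assay compound 2 gives > 100000 nM, again a limit.
Compound 3 `COc1c(Br)cc(Br)cc1C(=O)Nc1cccc(Cl)c1` — in this assay compound 3 gives > 100000 nM, again a limit.

Compound 1 therefore stands only at a limit in this assay, and so do both other measured compounds; all three sit at the limit of > 100000 nM in this assay, at which 3 of the 3 values shown sit. The steps among them carry no readable size: a step that the two limits leave unreadable from compound 1 to compound 2, a step that the two limits leave unreadable from compound 1 to compound 3 and a step that the two limits leave unreadable from compound 2 to compound 3 are each hidden by the two limits.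

Compound 4 `O=C(Nc1cccc(Cl)c1)c1cccc(Br)c1O` differs from compound 1 by hydrogen in place of bromo on an aromatic carbon. Within the data shown here, no measured step touches this bromo group, and the steps that exist, at the hydroxy and its methyl ether, are all unreadable, so they give no direction and no size beyond the scatter to expect in this assay. With every measured value of the series at the limit, the expectation for compound 4 is that it also stays at the limit in this assay, so the step from compound 1 to compound 4 is expected to be a number no higher from compound 1 to compound 4 (the limit leaves the size open). Compound 4 is thus estimated at 100000 nM, with a range from 30000 nM to 300000 nM, most probably reported only as a limit.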

Compound 4, half-maximal inhibitory concentration: > 100000 nM
Compound 4: only a limit was reported; the forecaster's own chance of this, stated with the estimate: 85%; the middle value sits exactly at the limit.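

In this assay compound 4 gives > 100000 nM, again a limit and not a number. Among these compounds, compound 1 and compound 4 thus both stand at a limit, so the step between them cannot be read and no new step follows: the limit of > 100000 nM in this assay, at which 4 of the 4 values shown sit. The compounds shown leave open how the hydroxy, methoxy and bromo groups bear on inhibition in this assay.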